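A new side group on compound 1

The source may hold more compounds than are shown below. What is called first, only, known or untested is meant among the compounds shown, and "the series" means these compounds.

In an ADME assay on HOS cells (Homo sapiens) for cytotoxicity (on this read-out higher numbers stand for lower toxicity in this test and lower numbers for higher toxicity in this test), compound 1 (`CN1CCCC(Cn2c(CN(C)C3CCCc4cccnc43)nc3ccccc32)C1`) gives 3000 nM while compound 2 (`CN1CCC[C@H](Cn2c(CN(C)[C@H]3CCCc4cccnc43)nc3ccccc32)C1`) gives 3600 nM and compound 3 (`CN1CCC[C@@H](Cn2c(CN(C)[C@H]3CCCc4cccnc43)nc3ccccc32)C1`) gives 3500 nM in the same test, so compound 1 stands level with both within the scatter. Compound 4 (`CN1CCCCC1CCn1c(CN(C)C2CCCc3cccnc32)nc2ccccc21`) carries (1-methylpiperidin-2-yl)methyl in place of 1-methylpiperidin-3-yl on a saturated chain carbon bound to an aromatic nitrogen. Going by the values given here, only three measured steps bear on this, all within the scatter and none changing atoms or bonds: (a 1.2-fold higher number from compound 1 to compound 2 (0.08 log units; within the scatter)) as well as (a 1.2-fold higher number from compound 1 to compound 3 (0.07 log units; within the scatter)) and (a 1.0-fold lower number from compound 2 to compound 3 (0.01 log units; within the scatter)). On these small steps alone, no step beyond the scatter is expected in this assay, and the estimated change is (no change at the digits printed from compound 1 to compound 4 (within the scatter)). For compound 4 the expected value is 3000 nM within an estimated range from 1200 nM to 7500 nM in this test.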

Compound 4, half-maximal cytotoxic concentration: 4900 nM
Compound 4: middle estimate off by 1.6-fold (0.21 log units), on the low side, and the stated range covers the measured number.
By their numbers in this assay, from the lowest: compounds 1, 3, 2 and 4 (each within the scatter of the next).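

The earlier steps shown here changed only the configuration as drawn, whereas this one changes the side group itself: in this assay, (1-methylpiperidin-2-yl)methyl in place of 1-methylpiperidin-3-yl gives a 1.6-fold higher number from compound 1 to compound 4 (0.21 log units; within the scatter) and stays within the scatter. This place therefore takes a change of atoms, not only of configuration, without a step beyond the scatter on this read-out. Nothing on hand explains this result.

Going by these compounds, whether a carboxylic acid or a longer chain on this saturated chain carbon would also stay within the scatter remains open. So does the part that configuration plays in compound 4, which is drawn without one.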